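The source may hold more compounds than are shown below. What is called first, only, known or untested is meant among the compounds shown, and "the series" means these compounds.

Measured so far:
compound 1 `COc1ccc(OC)c(-c2cc(-c3ccccc3)nn2-c2ccc(S(=O)(=O)NC(C)=O)cc2)c1` — 44500 nM
compound 2 `NS(=O)(=O)c1ccc(-n2nc(-c3ccccc3)cc2-c2cc(O)ccc2O)cc1` — 96000 nM

In a functional assay on cells (Cancer cell lines, Homo sapiens) for cytotoxicity, read by sulforhodamine B assay, with a stated time of 48 h (on this read-out higher numbers stand for weaker inhibition of growth and lower numbers for stronger inhibition of growth), compound 2 gives the higher of the two numbers; compound 1, the nearest, gives 44500 nM, and the two differ beyond the scatter. The two compounds differ in more than one place, so nothing isolates the sulfonamide change.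

Compound 3 `CC(=O)NS(=O)(=O)c1ccc(-n2nc(-c3ccccc3)cc2-c2cc(O)ccc2O)cc1` carries acetyl in place of hydrogen on a sulfonamide nitrogen, that is acetyl in place of hydrogen on a sulfonamide nitrogen. Going by the values given here, no measured pair shows this change alone, so the expected step of a 1.5-fold lower number from compound 2 to compound 3 (0.17 log units; within the scatter) is small, in either direction or none beyond the scatter. Compound 3 is estimated at 65000 nM, with a range from 20000 nM to 180000 nM.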

Compound 3, concentration for total growth inhibition: 100000 nM
Beside the measured number, compound 3's estimate is 1.5-fold (0.19 log units) below it; the measured number falls inside the stated range.
By their numbers in this assay, from the lowest: compound 1; then compounds 2 and 3 (each within the scatter of the next).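

Acetyl in place of hydrogen on a sulfonamide nitrogen leaves the number within the scatter in this assay with a 1.0-fold higher number from compound 2 to compound 3 (0.02 log units; within the scatter) as the step. The aryl group moves it further: 2,5-dihydroxyphenyl in place of 2,5-dimethoxyphenyl on an aromatic carbon gives a 2.2-fold higher number from compound 1 to compound 3 (0.35 log units; beyond the scatter) and so a modest shift toward weaker inhibition of growth. Nothing available accounts for either step.

Open, as far as these compounds go, is whether acetyl stays as silent alongside 2,5-dimethoxyphenyl. Also open, from the compounds shown here alone, is how a longer acyl chain or a carboxylic acid on the sulfonamide nitrogen would read.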